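Replacing 2,6-difluorophenyl by (thiophen-2-yl)methyl in the series

The source may report more compounds than this note shows. Statements on the series, on what has been measured and on what is new or still open speak of the compounds shown alone.

Compound 1, `C=CC(=O)Nc1cc(Nc2ncc(Cl)c(Nc3ccc(F)c(Cl)c3)n2)c(OC)cc1N1CCN(C)CC1`: 100 nM in a functional assay on NCI-H1975 cells (Homo sapiens) for inhibition, read by CellTiter-Glo, with a stated time of 72 h; a higher number here means a weaker inhibitor of growth, a lower number a stronger inhibitor of growth
Compound 2, `C=CC(=O)Nc1cc(Nc2ncc(Cl)c(Nc3c(F)cccc3F)n2)c(OC)cc1N1CCN(C)CC1`: 130 nM in this assay

For the measured compounds named here, compound 2 and compound 1 lie within the scatter of each other, the only measured step being a 1.3-fold higher number from compound 1 to compound 2 (0.11 log units; within the scatter). Compound 3, `C=CC(=O)Nc1cc(Nc2ncc(Cl)c(NCc3cccs3)n2)c(OC)cc1N1CCN(C)CC1`, differs from compound 2 by (thiophen-2-yl)methyl in place of 2,6-difluorophenyl on a nitrogen on an aromatic ring. Going by the values given here, no measured step covers this kind of change; the one available step only swaps one six-membered aromatic ring for another and stays within the scatter, so it gives little guidance. A weakening beyond the scatter in this assay is expected, with wide uncertainty. Compound 3 is therefore estimated at 400 nM, range 100 nM to 2000 nM. This estimate corresponds to an expected step of a 3.1-fold higher number from compound 2 to compound 3 (0.49 log units; beyond the scatter).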

Compound 3, concentration for 50% growth inhibition: 220 nM
The estimate for compound 3 lay 1.8-fold (0.26 log units) above the measured number; measured number inside the range.
By their numbers in this assay, from the lowest: compounds 1, 2 and 3 (each within the scatter of the next, the first and the last beyond it).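

At the nitrogen on the aromatic ring, a 1.7-fold higher number from compound 2 to compound 3 (0.23 log units; within the scatter) in this assay shows that (thiophen-2-yl)methyl, with its five-membered aromatic ring, can stand in place of 2,6-difluorophenyl without a step beyond the scatter. Against 3-chloro-4-fluorophenyl, a 2.2-fold higher number from compound 1 to compound 3 (0.34 log units; beyond the scatter) gives the only step beyond the scatter so far, and it is modest. No supporting data bear on either step.

Still open, as far as these compounds go, is whether a longer chain, such as 2-(thiophen-2-yl)ethyl, or a benzyl group on this nitrogen would stay in this range.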